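The source may report more compounds than this note shows. Statements on the series, on what has been measured and on what is new or still open speak of the compounds shown alone.

Compound 1 `Cc1cc(=O)n(-c2ccc(Br)cc2F)nc1C(=O)Nc1ccc(Oc2ncnc3[nH]ccc23)c(F)c1` gives 13300 nM.
Compound 2 `Cc1cc(=O)n(-c2ccc(Br)cc2F)nc1C(=O)Nc1ccc(Oc2ncnc3c2ccn3C)cc1` gives 18800 nM.
Compound 3 `Cc1cc(=O)n(-c2ccccc2OC(F)(F)F)nc1C(=O)Nc1ccc(Oc2ncnc3c2ccn3C)c(F)c1` gives > 60000 nM.

All three numbers come from a functional assay on PC-3 cells (Homo sapiens) for cytotoxicity, read by MTT assay, with a stated time of 72 h; a lower number here means a stronger inhibitor, a higher number a weaker inhibitor. Compound 1 at 13300 nM and compound 2 at 18800 nM lie within the usual scatter of each other, so no order between them is claimed. Compound 3 returns only > 60000 nM in this assay, which is a limit of the assay and not a number. It stands at the limit of > 60000 nM in this assay, at which 1 of the 3 values shown sits, and the place of compound 3 in this assay can only be given as that limit. Going by the values given here, no pair of measured compounds differs in a single place, so no measured step is available.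

Compound 4 `Cc1cc(=O)n(-c2ccc(Br)cc2F)nc1C(=O)Nc1ccc(Oc2ncnc3c2ccn3C)c(F)c1` differs from compound 3 in one place: 4-bromo-2-fluorophenyl in place of 2-(trifluoromethoxy)phenyl on an aromatic nitrogen. This is the 4-bromo-2-fluorophenyl group that compound 1 and compound 2 carry on the aromatic nitrogen; compound 1 gave 13300 nM and compound 2 gave 18800 nM, both measurable. Compound 3 with 2-(trifluoromethoxy)phenyl returned only a limit of the assay. A gain beyond the scatter is therefore expected, an at least 4.0-fold lower number from compound 3 to compound 4 (0.60 log units; beyond the scatter), bringing compound 4 into the range of the two measured analogues. Compound 4 is estimated at 15000 nM in this assay, with a range from 6000 nM to 40000 nM.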

Compound 4, half-maximal inhibitory concentration: 6670 nM
Beside the measured number, compound 4's estimate is 2.2-fold (0.35 log units) above it; the range from low to high includes it.
By their numbers in this assay, from the lowest: compounds 4, 1 and 2 (each within the scatter of the next, the first and the last beyond it). At a limit, above all of these: compound 3.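

With the rest of the molecule unchanged, 4-bromo-2-fluorophenyl in place of 2-(trifluoromethoxy)phenyl on the aromatic nitrogen gives, in this assay, an at least 8.9-fold lower number from compound 3 to compound 4 (0.95 log units; beyond the scatter), the only single-place reading at this position among the compounds shown. That size is only a bound, as compound 3 stands at a limit of the assay: the limit of > 60000 nM in this assay, at which 1 of the 4 values shown sits. Compound 4 also connects the two earlier measured compounds: fluoro in place of hydrogen on an aromatic carbon gives a 2.8-fold lower number from compound 2 to compound 4 (0.45 log units; beyond the scatter), a change beyond the scatter, whereas methyl in place of hydrogen on an aromatic nitrogen gives a 2.0-fold lower number from compound 1 to compound 4 (0.30 log units; within the scatter), which stays within it.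

Going by these compounds, the bromo and the fluoro of the 4-bromo-2-fluorophenyl group remain unseparated, so it is open which of them, if either, carries the step from the 2-(trifluoromethoxy)phenyl compound. Also open, on these data alone, is how a phenyl group bearing an amine such as morpholine, or a carboxylic acid, would read at this position in this assay, and whether the step holds on the core of compound 1.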